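Aryl swap on the cyclopropane of the biphenyl amides

This account rests on a few compounds, and the source may have more. Where it says the series, first, only, none or still open, it means among the compounds named here.

Measured so far in a functional assay for agonist activity at G protein-coupled receptor 88 (Homo sapiens), read by HTRF and cAMP accumulation; on this read-out higher numbers stand for an effect only at larger amounts of compound and lower numbers for an effect already at smaller amounts:
compound 1 `CC(C)CCNCCN(C(=O)[C@@H]1C[C@H]1c1ccccc1)c1ccc(-c2ccccc2)cc1`: 5.1 nM
compound 2 `CC[C@H](C)[C@H](N)CN(C(=O)[C@@H]1C[C@H]1c1ccccc1F)c1ccc(-c2ccccc2)cc1`: 650 nM

Compound 2 holds the highest number of the two; compound 1 gives the far lower value, and the gap is beyond the scatter. The two differ in more than one place, so only their values are set side by side. Compound 3 `CC[C@H](C)[C@H](N)CN(C(=O)[C@@H]1C[C@H]1c1ccccn1)c1ccc(-c2ccccc2)cc1` carries pyridin-2-yl in place of 2-fluorophenyl on a saturated ring carbon. For the measured compounds named here, no measured pair shows this change, so the step is expected to be small, estimated as a 1.4-fold higher number from compound 2 to compound 3 (0.14 log units; within the scatter), if anything toward a higher number. Compound 3 is expected to give about 900 nM in this assay, within 300 nM to 3000 nM.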

Compound 3, half-maximal effective concentration: 130 nM
Compound 3: middle estimate off by 6.9-fold (0.84 log units), on the high side, and the stated range ends above it.
By their numbers in this assay, from the lowest: compound 1; then compound 3; then compound 2.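

In this assay, the group on this saturated ring carbon moves the number on its own: with the rest of compound 2 unchanged, pyridin-2-yl in place of 2-fluorophenyl gives a 5.0-fold lower number from compound 2 to compound 3 (0.70 log units; beyond the scatter). A ring nitrogen is therefore tolerated here, and the lower number comes with the change of ring. Nothing measured accounts for the step.

Still open, on these data alone, is whether the ring nitrogen or the loss of fluorine carries the step, which plain phenyl on this same chain would separate. Also open, as far as these compounds go, are pyridin-3-yl, pyridin-4-yl and pyrimidinyl, and whether the step carries over to the side chain of compound 1.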